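Series notes: isopropoxy in place of 4-nitrophenyl on the carbonyl

The source may hold more compounds than are shown below. What is called first, only, known or untested is meant among the compounds shown, and "the series" means these compounds.

Of the compounds shown here, three of the shared core have been measured in a functional assay on HCT-116 cells (Homo sapiens) for cytotoxicity, read by MTT assay; a lower number here means a stronger inhibitor, a higher number a weaker inhibitor. Compound 1 `CCc1cc(S(=O)(=O)N2C[C@H](c3ccccc3)NC2=O)ccc1NC(=O)c1ccc(N)cc1` gives 460 nM. Compound 2 `CCCCOC(=O)Nc1ccc(S(=O)(=O)N2C[C@H](c3ccccc3)NC2=O)cc1CC` gives 200 nM. Compound 3 `CCc1cc(S(=O)(=O)N2C[C@H](c3ccccc3)NC2=O)ccc1NC(=O)c1ccc([N+](=O)[O-])cc1` gives 500 nM, the highest of the three numbers; a 1.1-fold higher number from compound 1 to compound 3 (0.04 log units; within the scatter) lies within the scatter, while a 2.5-fold higher number from compound 2 to compound 3 (0.40 log units; beyond the scatter) lies beyond it. Compound 4 `CCc1cc(S(=O)(=O)N2C[C@H](c3ccccc3)NC2=O)ccc1NC(=O)OC(C)C` is not yet measured; it differs from compound 3 by isopropoxy in place of 4-nitrophenyl on a carbonyl carbon. Going by the values given here, the steps that bear on this exchange a butoxy for a 4-aminophenyl or a 4-nitrophenyl on the same carbonyl carbon: a 2.3-fold lower number from compound 1 to compound 2 (0.36 log units; beyond the scatter) and a 2.5-fold higher number from compound 2 to compound 3 (0.40 log units; beyond the scatter). Both give the butoxy compound the lower number by a modest margin, and isopropoxy is taken to behave like butoxy. A step of like size and direction is therefore expected, a 2.3-fold lower number from compound 3 to compound 4 (0.36 log units; beyond the scatter). In this assay compound 4 is estimated at 220 nM, between 100 nM and 450 nM.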

Compound 4, half-maximal inhibitory concentration: 60 nM
Beside the measured number, compound 4's estimate is 3.7-fold (0.56 log units) above it; the measured number lies below the stated range.
By their numbers in this assay, from the lowest: compound 4; then compound 2; then compounds 1 and 3 (each within the scatter of the next).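

In this assay, isopropoxy on the carbonyl carbon gives a much lower number than either aromatic group, with an 8.3-fold lower number from compound 3 to compound 4 (0.92 log units; beyond the scatter) and a 7.7-fold lower number from compound 1 to compound 4 (0.88 log units; beyond the scatter). The two alkoxy groups are also not interchangeable here: isopropyl in place of butyl on an oxygen next to a carbonyl group gives a 3.3-fold lower number from compound 2 to compound 4 (0.52 log units; beyond the scatter). No measurement at hand accounts for these steps.

With only butyl and isopropyl on that oxygen, chain length and branching cannot be told apart. A propyl or tert-butyl group there would separate them.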